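Putting a methyl on the hydroxy of compound 2

A few compounds are considered here, and "the series" means these few. Any claim that something is new, unique, unknown or untested is made for them only; others in the source may bear on it.

Among the measured compounds shown here, in a functional assay on A2780 cells (Homo sapiens) for inhibition, read by sulforhodamine B assay (on this read-out higher numbers stand for weaker inhibition of growth and lower numbers for stronger inhibition of growth), compound 2 (`Oc1ccc(-c2ccc(-c3ccc(-c4nc5c(O)cccc5[nH]4)cc3)cc2)cc1`) gives 2920 nM as the lower of the two numbers so far. Compound 1 (`Oc1cccc2[nH]c(-c3ccc(-c4ccc(-c5ccccc5)cc4)cc3)nc12`) gives 41000 nM with hydrogen where compound 2 carries its extra hydroxy. For the measured compounds named here, the one measured step that bears on this group is large, namely a 14-fold lower number from compound 1 to compound 2 (1.15 log units; beyond the scatter) with hydroxy in place of hydrogen on an aromatic carbon. Compound 3 (`COc1ccc(-c2ccc(-c3ccc(-c4nc5c(O)cccc5[nH]4)cc3)cc2)cc1`) has methyl in place of hydrogen on an oxygen on an aromatic ring and so turns hydroxy into methoxy. The oxygen stays, and a partial return toward the higher number is expected, not a full reversal of a 14-fold lower number from compound 1 to compound 2 (1.15 log units; beyond the scatter) in these data. The estimated change is a 2.4-fold higher number from compound 2 to compound 3 (0.38 log units; beyond the scatter) with weaker inhibition of growth expected. Compound 3 is estimated at 7000 nM with an expected range of 2500 nM to 20000 nM in this assay for now.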

Compound 3, concentration for 50% growth inhibition: 8640 nM
The estimate for compound 3 lay 1.2-fold (0.09 log units) below the measured number; measured number inside the range.
By their numbers in this assay, from the lowest: compound 2; then compound 3; then compound 1.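

In this assay the hydrogen on this oxygen counts for something: turning hydroxy into methoxy gives a 3.0-fold higher number from compound 2 to compound 3 (0.47 log units; beyond the scatter) and so gives back part of the gain seen with the hydroxy. The methoxy still does better than hydrogen on the same aromatic carbon, with a 4.7-fold lower number from compound 1 to compound 3 (0.68 log units; beyond the scatter) as the step, so a capped oxygen keeps some of the benefit. The order at this place is thus hydroxy, then methoxy, then hydrogen, but nothing measured here explains that order.

From the compounds shown here alone, it remains open how much room this position has, for example for a longer chain on the oxygen such as ethoxy, or for an amine or a carboxylic acid in place of the hydroxy. Going by these compounds, all three compounds also keep the other hydroxy on the core, so its contribution remains open too.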